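The compounds below may be only part of what the source reports. "The series", "measured", "known", "first", "only" and "open" are said of these compounds alone.

Of the compounds shown here, three that share one core have been tested in an ADME assay on MRC5 cells (Homo sapiens), read by MTT assay, with a stated time of 72 h (a higher number here means a weaker inhibitor, a lower number a stronger inhibitor), a test of how strongly each compound harms a line of human cells. Compound 1 `Cc1nc(N)c2c(-c3cccs3)cn([C@@H]3O[C@H](CO)[C@@H](O)[C@H]3O)c2n1` gives only a limit here, > 100000 nM, meaning that no harm was measured up to the highest concentration tried. Compound 2 `CN(C)c1ncnc2c1c(-c1ccsc1)cn2[C@@H]1O[C@H](CO)[C@@H](O)[C@H]1O` likewise reaches only the limit of > 100000 nM. Compound 3 `Nc1nc(N)c2c(-c3ccco3)cn([C@@H]3O[C@H](CO)[C@@H](O)[C@H]3O)c2n1` also sits at the limit, > 100000 nM. Among the compounds with values here, compound 1 therefore stands exactly where every compound measured so far stands: at the limit, with no number to compare. All three readings rest at the limit of > 100000 nM in this assay, at which 3 of the 3 values shown sit, so no step between measured compounds can be drawn, and no group on the core has yet been shown to matter for this readout.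

Compound 4 `C#Cc1cn([C@@H]2O[C@H](CO)[C@@H](O)[C@H]2O)c2nc(C)nc(N)c12` differs from compound 1 in one place: ethynyl in place of thiophen-2-yl on an aromatic carbon. The thiophen-2-yl group leaves and an ethynyl group enters on that aromatic carbon of the core. Nothing in the numbers suggests that this change should turn a compound that does no measurable harm into one that does. For compound 4 the expected step is a number no higher from compound 1 to compound 4 (the limit leaves the size open), which is none beyond the usual scatter. Compound 4 is expected to give 100000 nM in this assay, within a range from 40000 nM to 300000 nM, and most likely to be reported again only as a limit.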

Compound 4, half-maximal inhibitory concentration: > 100000 nM
Compound 4: only a limit was reported (the forecaster's own chance of this, stated with the estimate: 85%); the middle value lies on the limit itself.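

Within the data shown here, compound 1 and compound 4 both give only a limit in this assay, so the change from thiophen-2-yl to ethynyl yields no step that can be read. The compounds shown leave open whether any group on the shared core changes this readout at all, since no reading is yet a number: the limit of > 100000 nM in this assay, at which 4 of the 4 values shown sit.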